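The source may report more compounds than this note shows. Statements on the series, on what has been measured and on what is new or still open speak of the compounds shown alone.

In a functional assay (Cavia porcellus) with sulfonylurea receptors; K-ATP channels (Homo sapiens) as the target (a lower number here means a stronger inhibitor, a higher number a weaker inhibitor), three close relatives of compound 4 have already been measured. Compound 1 `CC(O)(C(=O)Nc1ccc(S(=O)(=O)c2cccc(F)c2)cc1)C(F)(F)F` gives 3400 nM. Compound 2 `COc1ccccc1S(=O)(=O)c1ccc(NC(=O)C(C)(O)C(F)(F)F)cc1` gives 1600 nM. Compound 3 `CC(O)(C(=O)Nc1ccc(S(=O)(=O)c2ccc(Br)cc2)cc1)C(F)(F)F` reaches only the limit of this assay, > 30000 nM, so no number is known for it, and among the values shown it stands as the weakest, with the limit of > 30000 nM in this assay, at which 1 of the 3 values shown sits, marking where it sits. Compound 4 `CC(O)(C(=O)Nc1ccc(S(=O)(=O)c2nccs2)cc1)C(F)(F)F` differs from compound 3 by 1,3-thiazol-2-yl in place of 4-bromophenyl on a sulfonyl sulfur. Among the compounds with values here, two measured steps bear on this place: an at least 8.8-fold higher number from compound 1 to compound 3 (0.94 log units; beyond the scatter) and an at least 18-fold higher number from compound 2 to compound 3 (1.27 log units; beyond the scatter), both showing that 4-bromophenyl on the sulfonyl sulfur goes with a weaker result than another group there. The change is therefore expected to bring a lower number, an at least 6.0-fold lower number from compound 3 to compound 4 (0.77 log units; beyond the scatter). Compound 4 is estimated at 5000 nM, within 1500 nM to 30000 nM.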

Compound 4, half-maximal inhibitory concentration: 1400 nM
The estimate for compound 4 lay 3.6-fold (0.55 log units) above the measured number; the measured number lies below the stated range.
By their numbers in this assay, from the lowest: compounds 4 and 2 (each within the scatter of the next); then compound 1. At a limit, above all of these: compound 3.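

In this assay, 1,3-thiazol-2-yl in place of 4-bromophenyl gives an at least 21-fold lower number from compound 3 to compound 4 (1.33 log units; beyond the scatter), which shows that this place on the sulfonyl sulfur also tolerates a five-membered aromatic ring with 2 hetero atoms. The same ring gives a 1.1-fold lower number from compound 2 to compound 4 (0.06 log units; within the scatter) and a 2.4-fold lower number from compound 1 to compound 4 (0.39 log units; beyond the scatter), so compounds 2 and 4 cannot be told apart, while compound 4 has the lower number of the pair with compound 1. The figure for compound 3 remains only a limit: the limit of > 30000 nM in this assay, at which 1 of the 4 values shown sits.

The compounds shown leave open how a pyridyl ring, an unsubstituted phenyl or an amine on the sulfonyl sulfur would compare. They also cannot tell which of the thiazole's two hetero atoms, if either, matters here.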